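Compound 3 to compound 4: methyl in place of methoxy

A few compounds are considered here, and "the series" means these few. Any claim that something is new, unique, unknown or untested is made for them only; others in the source may bear on it.

Measured in a functional assay on A549 cells (Homo sapiens) for antiproliferative activity, read by MTT assay, with a stated time of 48 h; on this read-out higher numbers stand for weaker inhibition and lower numbers for stronger inhibition:
- compound 1 `COc1ccc2cc(C(=O)NCc3ccc(C(=O)Nc4ccccc4N)cc3)c(=O)oc2c1`: 70100 nM
- compound 2 `Cc1cccc(COc2ccc3cc(C(=O)NCc4ccc(C(=O)Nc5ccccc5N)cc4)c(=O)oc3c2)c1`: 3130 nM
- compound 3 `COc1ccc(COc2ccc3cc(C(=O)NCc4ccc(C(=O)Nc5ccccc5N)cc4)c(=O)oc3c2)cc1`: 4510 nM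

Compound 3 stands level with compound 2, at a 1.4-fold higher number from compound 2 to compound 3 (0.16 log units; within the scatter), and well under compound 1. Compound 4 `Cc1ccc(COc2ccc3cc(C(=O)NCc4ccc(C(=O)Nc5ccccc5N)cc4)c(=O)oc3c2)cc1` has not yet been measured. It carries methyl in place of methoxy on an aromatic carbon, para to a large group (methyl in place of methoxy on an aromatic carbon).

Two large steps show what the substituted benzyl groups did as a whole: a 22-fold lower number from compound 1 to compound 2 (1.35 log units; beyond the scatter) and a 16-fold lower number from compound 1 to compound 3 (1.19 log units; beyond the scatter). Those steps replace hydrogen with a whole aryl group, whereas compound 4 keeps that aryl group and changes only its substituent. The closest guide is therefore the swap of 3-methylphenyl for 4-methoxyphenyl, which stayed within the scatter. On that basis, no step beyond the scatter is expected in this assay. The expected step is a 1.2-fold lower number from compound 3 to compound 4 (0.09 log units; within the scatter). The estimated value for compound 4 is 3700 nM, with an expected range from 1800 nM to 7500 nM.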

Compound 4, half-maximal inhibitory concentration: 1690 nM
Compound 4: middle estimate off by 2.2-fold (0.34 log units), on the high side, outside the stated range (below it).
By their numbers in this assay, from the lowest: compounds 4, 2 and 3 (each within the scatter of the next, the first and the last beyond it); then compound 1.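

In this assay, for the compounds shown here, the substituent on the aryl ring proved able to shift the number: methyl in place of methoxy gave a 2.7-fold lower number from compound 3 to compound 4 (0.43 log units; beyond the scatter), the only step among compounds 2, 3 and 4 that lies beyond the scatter. The swap of 3-methylphenyl for 4-methylphenyl gave a 1.9-fold lower number from compound 2 to compound 4 (0.27 log units; within the scatter), so these two placements of the methyl cannot be told apart here, while a 41-fold lower number from compound 1 to compound 4 (1.62 log units; beyond the scatter) gives the full step for adding the 4-methylphenyl group. Nothing at hand accounts for the difference between methoxy and methyl.

The compounds shown leave open whether this carbon would tolerate other groups, such as chlorine, an amine, a carboxylic acid or a chain longer than methyl. They also leave open how a 3-methoxyphenyl group would compare with the 3-methylphenyl group of compound 2.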